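Cyclobutyl in place of methyl: notes on compound 3

The source may hold more compounds than are shown below. What is called first, only, known or untested is meant among the compounds shown, and "the series" means these compounds.

Compound 1 `CCN(C(=O)OC)c1c(N)nc(-c2nn(Cc3ccccc3F)c3ncccc23)nc1N` and compound 2 `COC(=O)Nc1c(N)nc(-c2nn(Cc3ccccc3F)c3ncccc23)nc1N` have both been measured in an assay on cells for activation of Guanylate cyclase soluble subunit alpha-1 (Rattus norvegicus), read by cGMP accumulation and immunoassay, with a stated time of 10 min; on this read-out lower numbers stand for an effect already at smaller amounts and higher numbers for an effect only at larger amounts of compound. Compound 1 gives 0.2 uM, and compound 2 gives 0.3 uM. Among the measured compounds shown here, the only measured step between them is a 1.5-fold higher number from compound 1 to compound 2 (0.18 log units; within the scatter). Compound 2 thus holds the higher of the two numbers, but its gap to compound 1 is within the scatter, so no order between the two can be read from this assay. Compound 3 `Nc1nc(-c2nn(Cc3ccccc3F)c3ncccc23)nc(N)c1NC(=O)OC1CCC1` differs from compound 2 by cyclobutyl in place of methyl on an oxygen next to a carbonyl group. For the measured compounds named here, no measured step touches the oxygen next to the carbonyl group; the one step known concerns the amide-type nitrogen and stayed within the scatter, so it gives little guidance for the present change. Lacking a closer precedent, the step expected in this assay is no change at the digits printed from compound 2 to compound 3 (within the scatter), not beyond the scatter. Compound 3 is therefore estimated at 0.3 uM, with a range from 0.1 uM to 1 uM.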

Compound 3, minimum effective concentration: 0.2 uM
Compound 3: middle estimate off by 1.5-fold (0.18 log units), on the high side; measured number inside the range.
By their numbers in this assay, from the lowest: compounds 1, 3 and 2 (each within the scatter of the next).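

In this assay the oxygen next to a carbonyl group now has its first measured change, and cyclobutyl in place of methyl reads as a 1.5-fold lower number from compound 2 to compound 3 (0.18 log units; within the scatter) with no separation of the two groups at this position. The wider swap on the aromatic carbon, (cyclobutyloxycarbonyl)amino in place of ethyl(methoxycarbonyl)amino, gives no change at the digits printed from compound 1 to compound 3 (within the scatter) and so also separates nothing, which leaves the three compounds without an order in this read-out. No evidence is available that bears on this result.

Methyl and cyclobutyl are the only groups compared on this oxygen, so it remains open whether a longer chain, a phenyl ring or a group carrying an amine would also stay within the scatter. Also open, going by these compounds, is whether ethyl on the amide-type nitrogen together with cyclobutyl on the oxygen would give a number apart from those of compound 1 and compound 3.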